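The compounds below may be only part of what the source reports. "The series", "measured", "known", "first", "only" and "open" are said of these compounds alone.

In a functional assay on MDA-MB-231 cells (Homo sapiens) for antiproliferative activity, read by MTT assay, with a stated time of 72 h (a lower number here means a stronger inhibitor, a higher number a weaker inhibitor), compound 1 `CC1=CC[C@H]2[C@H](CC[C@]2(C)O)C(C)(C)[C@@H]1CC[C@H]1[C@]2(C)CC[C@H](OC(=O)c3ccncc3)C(C)(C)O[C@H]2CC[C@@]1(C)O` gives 18000 nM. Among the measured compounds shown here, compound 3 `CC1=CC[C@H]2[C@@H]1CC=C(C)[C@@H](CC[C@H]1[C@]3(C)CC[C@H](OC(=O)c4ccncc4)C(C)(C)O[C@H]3CC[C@@]1(C)O)C2(C)C` gives 19100 nM, within the scatter of compound 1, so these two stand level at the low end of the three numbers measured so far. Compound 2 `CC(=O)O[C@H]1CC[C@]2(C)[C@H](CC[C@@](C)(O)[C@H]2CC[C@@H]2C(C)=CC[C@@H]3C(C)=CC[C@@H]3C2(C)C)OC1(C)C` gives 39200 nM, a higher number that lies beyond the scatter of both.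

Compound 4 `CC1=CC[C@H]2[C@H](CC[C@]2(C)O)C(C)(C)[C@@H]1CC[C@H]1[C@]2(C)CC[C@H](OC(=O)NCc3ccccc3)C(C)(C)O[C@H]2CC[C@@]1(C)O` has not yet been measured. It keeps the core of compound 1 and differs in one place, with benzylamino in place of pyridin-4-yl on a carbonyl carbon.

For the measured compounds named here, only one measured step involves a change on such a carbonyl carbon. This is a 2.1-fold lower number from compound 2 to compound 3 (0.31 log units; beyond the scatter), a modest step that came with pyridin-4-yl in place of methyl. Going by the values given here, no measured compound carries benzylamino, so the data do not show which way this new group should move the number. Among the compounds with values here, with only that modest step as a guide, no change beyond the scatter is expected, and the estimate stays close to compound 1 at 18000 nM.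

The estimated step runs a 1.1-fold lower number from compound 1 to compound 4 (0.02 log units; within the scatter). Compound 4 is expected at about 17000 nM, with an estimated range of 7000 nM to 40000 nM.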

Compound 4, half-maximal inhibitory concentration: 40300 nM
Compound 4: middle estimate off by 2.4-fold (0.37 log units), on the low side; measured number outside the range, above it.
By their numbers in this assay, from the lowest: compounds 1 and 3 (each within the scatter of the next); then compounds 2 and 4 (each within the scatter of the next).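

In this assay, the change at this carbonyl carbon gives a 2.2-fold higher number from compound 1 to compound 4 (0.35 log units; beyond the scatter), so this position responds to what sits on the carbonyl even when the core of compound 1 stays the same. Together with the earlier step from methyl to pyridin-4-yl on a carbonyl carbon in a different core, this gives two measured steps at such a carbon, and in both the compound carrying pyridin-4-yl has the lower number, though both steps are modest and two steps make only a thin pattern. No measurement here explains why benzylamino gives the higher number.

The swap alters several things at once, since the ring loses its nitrogen, the amide hydrogen appears, and the link changes from ((pyridin-4-yl)carbonyl)oxy to (benzylcarbamoyl)oxy, so the compounds shown cannot say which of these matters. A plain phenyl group on the same carbonyl carbon would test the ring nitrogen on its own, a (pyridin-4-yl)methylamino group would keep that nitrogen alongside the amino link, and a free hydroxyl in place of the whole ester would show what the acyl part contributes at all.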